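This account rests on a few compounds, and the source may have more. Where it says the series, first, only, none or still open, it means among the compounds named here.

Of the compounds shown here, three have been measured in an assay on HEK293 cells for inhibition of N-acylethanolamine-hydrolyzing acid amidase (Rattus norvegicus), read by LC-MS, with a stated time of 30 min; a higher number here means a weaker inhibitor, a lower number a stronger inhibitor. Compound 1 `Cc1ccccc1CCCCCCC(=O)N1CCCC1` gives 68400 nM in this assay. Compound 2 `Cc1ccc(CCCCCCC(=O)N2CCCC2)cc1` gives 9600 nM in this assay. Compound 3 `O=C(CCc1ccc(-c2cccc(Cl)c2)cc1)N1CCCC1` gives 25400 nM in this assay. Among these three numbers compound 2 stands lowest; its nearest neighbour is compound 3, and that gap is beyond the scatter, while the gap to compound 1 is wider still and also beyond the scatter.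

Compound 4 `O=C(CCCCCCc1ccc(O)cc1)N1CCCC1` has not yet been measured. It differs from compound 2 in one place: hydroxy in place of methyl on an aromatic carbon, para to a large group. Going by the values given here, no pair among the measured compounds shows this same exchange, so there is no measured step to lean on. From compound 2 at 9600 nM the change is expected to bring a small step in this assay, if anything toward a higher number, and it may well stay within the scatter. The estimated step from compound 2 to compound 4 is a 1.6-fold higher number from compound 2 to compound 4 (0.19 log units; within the scatter). Compound 4 is therefore expected to give about 15000 nM in this assay, with a range from 4000 nM to 60000 nM.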

Compound 4, half-maximal inhibitory concentration: 5600 nM
Compound 4: the middle estimate sits 2.7-fold (0.43 log units) above what was measured; low and high end bracket the measured number.
By their numbers in this assay, from the lowest: compounds 4 and 2 (each within the scatter of the next); then compound 3; then compound 1.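

In this assay the exchange of methyl for hydroxy on an aromatic carbon, para to a large group, gives a 1.7-fold lower number from compound 2 to compound 4 (0.23 log units; within the scatter), so compound 2 and compound 4 cannot be told apart here. Going by these compounds alone, this is the first measured step at this position, and it shows that a group with one hydrogen-bond donor and one hydrogen-bond acceptor can stand in place of one with neither and leave the number within the scatter. Nothing at hand explains this result.

From the compounds shown here alone, it remains open whether a methoxy, an amine or a carboxylic acid at this same place would also leave the number within the scatter. Going by these compounds, whether the hydroxy would do the same on a longer chain also stays unknown, since this single pair speaks only for the chain that compound 2 and compound 4 share.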